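Shortening the carbonate ester from isobutyl toward methyl

A few compounds are considered here, and "the series" means these few. Any claim that something is new, unique, unknown or untested is made for them only; others in the source may bear on it.

compound 1 `CC(C)COC(=O)OCC(CO)CCn1cnc2cnc(N)nc21`: 2090 h
compound 2 `CC(C)OC(=O)OCC(CO)CCn1cnc2cnc(N)nc21`: > 4800 h

Among the compounds with values here, in an ADME assay for pharmacokinetics, read by HPLC, in phosphate buffer, at 37 degrees C, at pH 6.0 (on this read-out higher numbers stand for a longer-lived compound and lower numbers for a shorter-lived compound), compound 1 gives 2090 h, the only plain number among the two values shown. For compound 2 the result is a limit of the assay, > 4800 h. Within the data shown here, the one measured step, an at least 2.2-fold higher number from compound 1 to compound 2 (0.36 log units; beyond the scatter), sits at the limit of > 4800 h in this assay, at which 1 of the 2 values shown sits. Compound 3 `COC(=O)OCC(CO)CCn1cnc2cnc(N)nc21` differs from compound 1 by hydrogen in place of isopropyl on a saturated chain carbon bound to an oxygen next to a carbonyl group. Among the measured compounds shown here, only that step bears on this change, and it ran upward. Compound 3 is therefore expected to give a number near or somewhat above compound 1, an estimated step of a 1.2-fold higher number from compound 1 to compound 3 (0.08 log units; within the scatter). Compound 3 is estimated at 2500 h, ranging from 900 h to 7000 h.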

Compound 3, half-life: 432 h
Compound 3: the middle estimate sits 5.8-fold (0.76 log units) above what was measured; the whole stated range lies above it.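

The carbonate ester does not respond to shortening in one direction only: in this assay, isobutyl to methyl gives a 4.8-fold lower number from compound 1 to compound 3 (0.68 log units; beyond the scatter), whereas the earlier step to isopropyl ran upward. Isopropyl to methyl gives an at least 11-fold lower number from compound 2 to compound 3 (1.04 log units; beyond the scatter), which leaves compound 3 the shortest-lived of the three. For compound 2, > 4800 h is a limit of the assay, not a number.

Where between methyl and isopropyl the number climbs remains open, as an ethyl or a straight propyl chain would fall in that gap. As far as these compounds go, how a tert-butyl group or a longer chain would behave in this assay also stays unknown.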